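The source may report more compounds than this note shows. Statements on the series, on what has been measured and on what is new or still open speak of the compounds shown alone.

Compound 2 `COc1ccc(CNC(=N)[C@@H]2CCC(=O)N2Cc2ccccc2[N+](=O)[O-])cc1` has the highest of the two numbers measured in a functional assay on SH-SY5Y cells (Homo sapiens) for cytotoxicity, read by MTT assay, with stated times of 8 h, 30 min and 12 h, tested at 5 uM (a lower number here means a weaker effect, a higher number a stronger effect of the compound at the concentration tested), at 25.4%, though its nearest neighbour, compound 1 `N=C(NCc1ccccc1)[C@@H]1CCC(=O)N1Cc1ccccc1[N+](=O)[O-]`, stands within the scatter of it with 25.3% in this assay. Within the data shown here, the only measured step, a number 0.1 percentage points higher from compound 1 to compound 2 (within the scatter), changes a group on the benzyl attached to the amidine and shows no effect beyond the scatter. Compound 3 `COc1ccc(CNC(=N)[C@@H]2CCC(=O)N2Cc2ccc(C)cc2)cc1` differs from compound 2 at another site: 4-methylphenyl in place of 2-nitrophenyl on a saturated chain carbon bound to an amide-type nitrogen in a ring. Among the measured compounds shown here, no measured step touches this part of the shared core, so the one known step, a number 0.1 percentage points higher from compound 1 to compound 2 (within the scatter), bears on the new change only in showing that the readout in this assay has so far been insensitive to a peripheral substitution. On that basis no step beyond the scatter is expected, a number 1.4 percentage points lower from compound 2 to compound 3 (within the scatter), with broad uncertainty. Compound 3 is therefore estimated to give 24% in this assay, in a range from 10% to 40%.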

Compound 3, a percentage reported as activity, at one concentration (the size of the read-out at that concentration, not a potency): 29.5%
Compound 3: middle estimate off by 5.5 percentage points, on the low side, and the stated range covers the measured number.
By their numbers in this assay, from the lowest: compounds 1, 2 and 3 (each within the scatter of the next).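

In this assay, among these compounds, the first measured step at the saturated chain carbon bound to an amide-type nitrogen in a ring, a number 4.1 percentage points higher from compound 2 to compound 3 (within the scatter) in this exchange of 2-nitrophenyl for 4-methylphenyl, lies within the scatter. The earlier pair had tested only the benzyl on the amidine, so this result extends the picture to a second site and shows that, between compound 2 and compound 3, the read-out at the single tested concentration does not depend on keeping the nitro group. No independent measurement is available to explain this result.

The exchange alters both the substituent and its place on the ring, so the two cannot be separated here. On these data alone, whether 4-nitrophenyl, 2-methylphenyl or a ring carrying an amine or a carboxylic acid would read differently remains open.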